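The source may hold more compounds than are shown below. What is called first, only, known or untested is meant among the compounds shown, and "the series" means these compounds.

Compound 2 `CC(C)N/C(=N\C1=NCCN1C(C)C)Nc1ccc(Cl)c(Cl)c1` gives the only numerical read-out in an in vitro ADME assay on microsomes from liver (Mus musculus) for metabolic stability, read by LC-MS, tested at 1 uM (a higher number here means that the compound lasts longer, a lower number that the compound disappears faster), at 0.227 h. Compound 1 `CC(C)N1CCN=C1/N=C(\N)Nc1ccc(Cl)c(Cl)c1` reaches only a limit of the assay there, > 1 h. For the measured compounds named here, the single measured step, an at least 4.4-fold lower number from compound 1 to compound 2 (0.64 log units; beyond the scatter), concerns an amine nitrogen and not the carbon altered here. Compound 3 `CC(C)N1CCN=C1/N=C(/Nc1ccc(Cl)c(Cl)c1)N1CCCCC1` differs from compound 2 by piperidin-1-yl in place of isopropylamino on a carbon with a double bond to nitrogen. Going by the values given here, no measured step covers that kind of change, so no step beyond the scatter is expected. The estimated step is small: a 1.0-fold lower number from compound 2 to compound 3 (0.01 log units; within the scatter). Compound 3 is therefore estimated at 0.22 h in this assay, between 0.08 h and 0.6 h.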

Compound 3, half-life: 0.358 h
The estimate for compound 3 lay 1.6-fold (0.21 log units) below the measured number; the measured number falls inside the stated range.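

With piperidin-1-yl in place of isopropylamino on this carbon, this assay shows a 1.6-fold higher number from compound 2 to compound 3 (0.20 log units; within the scatter), so the ring and the loss of the hydrogen-bond donor leave no readable difference here. Piperidin-1-yl in place of amino gives an at least 2.7-fold lower number from compound 1 to compound 3 (0.44 log units; beyond the scatter), so a plain amino group at this place stands apart from both larger groups. Compound 1 holds a limit of the assay, so the true size of that step stays unknown: the limit of > 1 h in this assay, at which 1 of the 3 values shown sits.

Still open, from the compounds shown here alone, is whether methylamino or morpholin-4-yl on this carbon would stay close to compound 2 and compound 3 or come closer to compound 1.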